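The compounds below may be only part of what the source reports. "The series", "measured", "known", "first", "only" and "open" are said of these compounds alone.

Compound 2 `CCOC(=O)c1c(-c2ccc(Cl)cc2)cc(-c2ccccc2)nc1Nc1ccc(OC)cc1` gives 38.9% in a functional assay on the whole organism (strain Wister albino) for inhibition, with Rattus norvegicus as the target, read by paw edema, with stated times of 1 h and 4 h, at a dose of 50 mg/kg by the intraperitoneal route; a lower number here means less inhibition, a higher number more inhibition at the dose given (going by the name of the read-out); its only comparator, compound 1 `CCOC(=O)c1c(-c2ccc(Cl)cc2)cc(-c2ccccc2)nc1N1CCN(C)CC1`, gives 37.8%, and the step of a number 1.1 percentage points higher from compound 1 to compound 2 (within the scatter) lies within the scatter. Compound 3 `CCOC(=O)c1c(-c2ccc(Cl)cc2)cc(-c2ccccc2)nc1Nc1ccc(Cl)cc1` differs from compound 2 by chloro in place of methoxy on an aromatic carbon. Among the measured compounds shown here, no measured step bears directly on this change: the single recorded step exchanges (4-methoxyphenyl)amino for 4-methylpiperazin-1-yl and stays within the scatter. With nothing in the series pointing to a shift beyond the scatter, a step of about a number 0.9 percentage points lower from compound 2 to compound 3 (within the scatter) is expected for compound 3, whose estimated value is 38% with a range from 25% to 50%.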

Compound 3, a percentage reported as inhibition, in the whole organism at one dose (the size of the read-out at that dose, not a potency): 65.2%
For compound 3 the middle estimate is 27.2 percentage points below the measured one; the measured number lies above the stated range.
By their numbers in this assay, from the lowest: compounds 1 and 2 (each within the scatter of the next); then compound 3.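

In this assay, chloro in place of methoxy on the aromatic carbon para to a large group gives a number 26.3 percentage points higher from compound 2 to compound 3 (beyond the scatter), so a change at this carbon can move the read-out, which the earlier pair did not show. The (4-chlorophenyl)amino group also separates from 4-methylpiperazin-1-yl, with a number 27.4 percentage points higher from compound 1 to compound 3 (beyond the scatter), a separation that (4-methoxyphenyl)amino did not show. Nothing measured on these compounds explains the change. Open, on these data alone, is whether the gain is specific to chloro or also appears with fluoro, bromo or methyl at this carbon. Also open, as far as these compounds go, is whether it survives a carboxylic acid in place of the ethyl ester.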